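Side chain change from compound 3 to compound 4

The compounds below may be only part of what the source reports. "The series", "measured", "known", "first", "only" and "open" are said of these compounds alone.

In a functional assay on HepG2 cells (Homo sapiens) for antiproliferative activity, read by MTT assay, with a stated time of 72 h (a higher number here means a weaker inhibitor, a lower number a stronger inhibitor), compound 1 `O=C(N/N=C/c1ccc(O)cc1)Nc1ccc(Oc2ccnc3[nH]ccc23)cc1` gives 32200 nM and compound 2 `COc1ccc(/C=N/NC(=O)Nc2ccc(Oc3ccnc4[nH]ccc34)cc2)cc1` gives 9740 nM. Among the measured compounds shown here, compound 3 `CN(C)CCn1cccc1/C=N/NC(=O)Nc1ccc(Oc2ccnc3[nH]ccc23)cc1` has no number: it is reported as "not active" (no number reported), so it cannot be placed on the scale with the other two, and no measured step starts from it.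

Compound 4 `O=C(N/N=C/c1cccn1CCCN1CCCC1)Nc1ccc(Oc2ccnc3[nH]ccc23)cc1` differs from compound 3 in its side chain: (pyrrolidin-1-yl)methyl in place of dimethylamino on a saturated chain carbon, two bonds along the chain from an aromatic nitrogen. Cut one bond further out, the same difference reads 2-(dimethylamino)ethyl to 3-(pyrrolidin-1-yl)propyl.

For the measured compounds named here, the only measured step is a 3.3-fold lower number from compound 1 to compound 2 (0.52 log units; beyond the scatter). That modest step comes from methyl in place of hydrogen on an oxygen on an aromatic ring, a different change at a different place, so it sets no size for this one. Going by the values given here, with no number for compound 3 either, no step of any particular size or direction can be expected in this assay.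

The expectation therefore rests on the standing of the nearest structure, compound 3 at "not active" (no number reported), and is placed nearer compound 1 at 32200 nM than compound 2 at 9740 nM. A report without a number is expected to be about as likely as a measured value. Compound 4 is estimated at 35000 nM, with an expected range of 10000 nM to 100000 nM.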

Compound 4, half-maximal inhibitory concentration: 1420 nM
Beside the measured number, compound 4's estimate is 25-fold (1.39 log units) above it; measured number outside the range, below it.
By their numbers in this assay, from the lowest: compound 4; then compound 2; then compound 1.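

In this assay, among the compounds shown here, compound 3 carries no number, so no step to compound 4 at 1420 nM can be read. The compounds shown leave open how 2-(dimethylamino)ethyl and 3-(pyrrolidin-1-yl)propyl compare, and whether chain length or the pyrrolidine ring accounts for any difference. No measurement shown offers an explanation for this result.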